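Acetyl in Place of Hydroxy on a Weak Inhibitor

This account rests on a few compounds, and the source may have more. Where it says the series, first, only, none or still open, it means among the compounds named here.

Compound 1 `CC(C)c1cc(Cl)cc(C(C)C)c1OC(=O)NS(=O)(=O)Oc1c(C(C)C)cccc1C(C)C` and compound 2 `CC(C)c1cc(O)cc(C(C)C)c1OC(=O)NS(=O)(=O)Oc1c(C(C)C)cccc1C(C)C` share one core and differ in a single group. In an assay on liver for inhibition of sterol O-acyltransferase 1 (Rattus norvegicus), using microsomes (on this read-out higher numbers stand for weaker inhibition and lower numbers for stronger inhibition), compound 1 gives 42000 nM. Compound 2 reaches only the limit of this assay, > 50000 nM, so no number is known for it, (the limit of > 50000 nM in this assay, at which 1 of the 2 values shown sits). The step of an at least 1.1-fold higher number from compound 1 to compound 2 (0.07 log units; that floor lies within the scatter) has a floor that lies within the scatter. Compound 3 `CC(=O)c1cc(C(C)C)c(OC(=O)NS(=O)(=O)Oc2c(C(C)C)cccc2C(C)C)c(C(C)C)c1` carries acetyl in place of hydroxy on an aromatic carbon. No measured step covers an acetyl, and the one step shown stays within the scatter, so no change beyond the scatter is expected in this assay, a number no higher from compound 2 to compound 3 (the limit leaves the size open). For compound 3 the estimate is 50000 nM, ranging from 15000 nM to 160000 nM.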

Compound 3, half-maximal inhibitory concentration: 41800 nM
Beside the measured number, compound 3's estimate is 1.2-fold (0.08 log units) above it, within the range that was stated.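

Acetyl in place of chloro gives a 1.0-fold lower number from compound 1 to compound 3 (0.00 log units; within the scatter) in this assay and so, unlike the hydroxy compound, yields a second measured number at this position, with the two groups not told apart. The step of an at least 1.1-fold lower number from compound 2 to compound 3 (0.07 log units; that floor lies within the scatter) has no known size beyond that floor. Compound 2 remains a limit and not a number: the limit of > 50000 nM in this assay, at which 1 of the 3 values shown sits.

On these data alone, whether an amine, a carboxylic acid or a longer chain at this position would move the number beyond the scatter stays open. So does whether any group here gives stronger inhibition.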